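Swapping the Methyl on the Piperazine for a Chloropyridyl

A few compounds are considered here, and "the series" means these few. Any claim that something is new, unique, unknown or untested is made for them only; others in the source may bear on it.

Compound 1 `CC(C(=O)NCc1ccc(C(F)(F)F)nc1N1CCCC1)c1ccc(NS(C)(=O)=O)c(F)c1`: 0.6 nM
Compound 2 `CC(C(=O)NCc1ccc(C(F)(F)F)nc1N1CCCCCC1)c1ccc(NS(C)(=O)=O)c(F)c1`: 0.8 nM
Compound 3 `CC(C(=O)NCc1ccc(C(F)(F)F)nc1N1CCN(C)CC1)c1ccc(NS(C)(=O)=O)c(F)c1`: 146 nM

In a functional assay on CHO-K1 cells for antagonist activity at transient receptor potential cation channel subfamily V member 1 (Homo sapiens), read by FLIPR (on this read-out lower numbers stand for stronger inhibition and higher numbers for weaker inhibition), compound 3 gives the highest number of the three measured compounds. Its distance from the others is large: a 240-fold higher number from compound 1 to compound 3 (2.39 log units; beyond the scatter) and a 180-fold higher number from compound 2 to compound 3 (2.26 log units; beyond the scatter), whereas a 1.3-fold higher number from compound 1 to compound 2 (0.12 log units; within the scatter). Compound 4 `CC(C(=O)NCc1ccc(C(F)(F)F)nc1N1CCN(c2ncccc2Cl)CC1)c1ccc(NS(C)(=O)=O)c(F)c1` differs from compound 3 in one place: 3-chloropyridin-2-yl in place of methyl on an amine nitrogen in a ring. Going by the values given here, no measured step alters a substituent on that ring nitrogen, so the effect of this particular change has no direct precedent. The two large steps do show that the ring attached to the shared core governs much of the result, so a change within that ring is expected to move the number rather than leave it unchanged. A moderate downward step a 7.3-fold lower number from compound 3 to compound 4 (0.86 log units; beyond the scatter) is expected, with wide uncertainty. Compound 4 is estimated at 20 nM, between 3 nM and 150 nM.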

Compound 4, inhibition constant: 2.1 nM
The estimate for compound 4 lay 9.5-fold (0.98 log units) above the measured number, and the stated range ends above it.
By their numbers in this assay, from the lowest: compounds 1 and 2 (each within the scatter of the next); then compound 4; then compound 3.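

Going by these compounds alone, the amine nitrogen in the six-membered ring proves to be a sensitive position in this assay: the earlier compounds showed only that changing the whole ring could move the number, whereas here changing only the group on that nitrogen gives a 70-fold lower number from compound 3 to compound 4 (1.84 log units; beyond the scatter). Seven heavy atoms in place of one are therefore compatible with strong inhibition at this position. No evidence here explains the gain. The compounds shown do not separate the contribution of the chlorine from that of the pyridine ring. A plain phenyl or an unsubstituted pyridin-2-yl on that nitrogen would be the direct comparison.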